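The source may report more compounds than this note shows. Statements on the series, on what has been measured and on what is new or still open speak of the compounds shown alone.

The series shares one core, differing only in the group on the oxime oxygen. Compound 1 `CCOC(=O)CO/N=C/c1c(N)ncnc1Oc1ccc(NC(=O)C2(C(=O)Nc3ccc(F)cc3)CC2)cc1F` carries an ethoxycarbonyl there and gives 3.15 in a physicochemical assay for lipophilicity, using the shake flask method; on this read-out lower numbers stand for lower lipophilicity and higher numbers for higher lipophilicity. Compound 2 `CCCCO/N=C/c1c(N)ncnc1Oc1ccc(NC(=O)C2(C(=O)Nc3ccc(F)cc3)CC2)cc1F` carries a butyl group instead and gives 4.2 in this assay, which is the higher of the two numbers; the step of a number 1.05 log units higher from compound 1 to compound 2 (beyond the scatter) is the only measured one in the set. Compound 3 `Nc1ncnc(Oc2ccc(NC(=O)C3(C(=O)Nc4ccc(F)cc4)CC3)cc2F)c1/C=N/OC1CCCC1` is the next member, and its change from compound 2 is cyclopentyl in place of butyl on an oxygen. That single measured step, propyl in place of ethoxycarbonyl, is of a different kind from the present one, so it bears on compound 3 only by showing that the oxime oxygen substituent strongly governs the read-out. For the exchange of butyl for cyclopentyl the expected step in this assay is small, a number 0.20 log units higher from compound 2 to compound 3 (within the scatter), upward if anything and close to the scatter. Compound 3 is therefore estimated at 4.4, with a likely range from 3.9 to 4.9.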

Compound 3, partition coefficient: 4.27
The estimate for compound 3 lay 0.13 log units above the measured number, within the range that was stated.
By their numbers in this assay, from the lowest: compound 1; then compounds 2 and 3 (each within the scatter of the next).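

In this assay, cyclopentyl in place of butyl on an oxygen whose other neighbour is a double-bonded nitrogen gives a number 0.07 log units higher from compound 2 to compound 3 (within the scatter), so at this position a five-membered non-aromatic ring of carbon only and an open butyl chain cannot be told apart on this read-out. The earlier pair showed only that the read-out can move strongly with the group on this oxygen; this pair adds that a change from chain to ring among groups made only of carbon need not move it. The further step, a number 1.12 log units higher from compound 1 to compound 3 (beyond the scatter), lies beyond the scatter, as does a number 1.05 log units higher from compound 1 to compound 2 (beyond the scatter), so among these three compounds the clear separation lies between (ethoxycarbonyl)methyl and the two groups of carbon only. Nothing available offers an explanation for these numbers.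

The compounds shown leave open whether a longer chain or a larger carbon ring on this oxygen would stay within the scatter of butyl and cyclopentyl. They also leave open where a chain ending in an amine or a carboxylic acid would fall relative to the ethoxycarbonyl-bearing compound 1.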